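Swapping Methoxy for Chloro on a Nitro-Bearing Core

The source may hold more compounds than are shown below. What is called first, only, known or untested is meant among the compounds shown, and "the series" means these compounds.

Among the compounds with values here, compound 1 `COc1cccc(/C=C2\CCC/C(=C\c3cccc([N+](=O)[O-])c3)C2=O)c1` is one of two compounds measured so far in a functional assay on MCF7 cells (Homo sapiens) for cytotoxicity, read by MTT assay (on this read-out higher numbers stand for weaker inhibition and lower numbers for stronger inhibition), where compound 1 gives 4.17 ug/mL. The other is compound 2 `COc1cccc(/C=C2\CCC/C(=C\c3cccc([N+](=O)[O-])c3)C2=O)c1OC`, which in this assay gives 5.14 ug/mL. Within the data shown here, the only measured step, a 1.2-fold higher number from compound 1 to compound 2 (0.09 log units; within the scatter), adds a methoxy to one aromatic ring and leaves the number essentially where it was. Compound 1 thus stands alongside compound 2, the two numbers being within the scatter of each other, so neither can be called the stronger.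

Compound 3 `O=C1/C(=C/c2cccc(Cl)c2)CCC/C1=C\c1cccc([N+](=O)[O-])c1` differs from compound 1 in one place: chloro in place of methoxy on an aromatic carbon. Among the measured compounds shown here, no measured step shows a chloro entering or a methoxy leaving, so the closest guide is the single step in which a methoxy was added, which stayed within the scatter. The change in compound 3 is a swap of one small group for another on the same ring, and the expectation is that this assay will again move little; the step of a 1.1-fold higher number from compound 1 to compound 3 (0.03 log units; within the scatter) is estimated to stay within the usual scatter. Compound 3 is therefore expected to give about 4.5 ug/mL, within a range from 2 ug/mL to 10 ug/mL.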

Compound 3, half-maximal inhibitory concentration: 5.15 ug/mL
Compound 3: the middle estimate sits 1.1-fold (0.06 log units) below what was measured, within the range that was stated.
By their numbers in this assay, from the lowest: compounds 1, 2 and 3 (each within the scatter of the next).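

In this assay, going from 3-methoxyphenyl to 3-chlorophenyl gives a 1.2-fold higher number from compound 1 to compound 3 (0.09 log units; within the scatter) and so leaves the two compounds indistinguishable. Within the data shown here, the earlier step added a second methoxy to the ring, whereas this one replaces the methoxy itself, at the place meta to a large group, so it is the first direct test of whether that group can be exchanged. The exchange swaps two heavy atoms and one hydrogen-bond acceptor for a single chlorine with no acceptor, yet the numbers still cannot be separated, and no supporting measurement is available to explain this.

The compounds shown leave open whether this position would accept a very different group, such as an amine, a carboxylic acid or a longer alkoxy chain, since methoxy and chloro are the only two groups compared there and neither carries a net charge. Among these compounds, they also leave open whether the nitro group on the other ring matters, as it is present in all three compounds and no pair shows what happens when it is replaced.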